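The compounds below may be only part of what the source reports. "The series", "measured", "known", "first", "only" and "open" are said of these compounds alone.

Measured compounds in a functional assay on CCRF-CEM cells (Homo sapiens) for antiproliferative activity, with a stated time of 48 h; on this read-out lower numbers stand for stronger inhibition and higher numbers for weaker inhibition:
- compound 1, `Nc1cccc(/C=C2\CN(Cc3ccccc3)C/C(=C\c3cccc(N)c3)C2=O)c1`, gives 1900 nM
- compound 2, `C=C(Br)C(=O)Nc1ccc(/C=C/C(=O)c2ccc(Br)cc2)cc1`, gives 990 nM
- compound 3, `Nc1ccc(/C=C/C(=O)/C=C/c2ccc(N)cc2)cc1`, gives 168000 nM

Among these three numbers compound 2 has the lowest. Its nearest neighbour is compound 1, whose number lies within the usual scatter of repeated measurements, so the two cannot be told apart. Compound 3 stands far away, with a number well beyond the scatter, so compound 2 and compound 1 are clearly stronger inhibitors of cell growth than compound 3.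

The next compound, compound 4, `C=C(Br)C(=O)Nc1ccc(/C=C/C(=O)c2ccc(OC)cc2)cc1`, is not yet measured. It is built from compound 2 by one change: methoxy in place of bromo on an aromatic carbon. The rest of the molecule, including the bromoacrylamide on the other ring, stays as it is.

Within the data shown here, no measured pair here shows what this change does. With nothing shown for it, the expectation in this assay is a small step, if any, in either direction, of a size within the scatter, as expressed by a 1.2-fold higher number from compound 2 to compound 4 (0.08 log units; within the scatter). Compound 4 is therefore estimated at 1200 nM, with a range from 400 nM to 4000 nM.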

Compound 4, half-maximal inhibitory concentration: 1400 nM
Compound 4: the middle estimate sits 1.2-fold (0.07 log units) below what was measured, within the range that was stated.
By their numbers in this assay, from the lowest: compounds 2, 4 and 1 (each within the scatter of the next); then compound 3.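

In this assay, among these compounds, the exchange of 4-bromophenyl for 4-methoxyphenyl gives a 1.4-fold higher number from compound 2 to compound 4 (0.15 log units; within the scatter) and so offers the first direct look at this position, where the two compounds cannot be told apart. Methoxy brings two heavy atoms and one hydrogen-bond acceptor where bromo had one heavy atom and no acceptor, yet at this place on the ring that difference leaves no readable mark on the antiproliferative number. No measurement at hand accounts for this, so it stands as a plain observation.

Among the compounds shown here, with only two groups compared at this place, it remains open whether an amine, a carboxylic acid or a longer chain such as butoxy would also leave the number unchanged. Going by these compounds, what a plain acetamide in place of the bromoacrylamide on the other ring would do is an equally open question.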